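From Phenyl to 4-Hydroxyphenyl on an Inactive Core

The source may hold more compounds than are shown below. What is called first, only, known or untested is meant among the compounds shown, and "the series" means these compounds.

Of the compounds shown here, two have so far been measured in a functional assay on Ehrlich cells (Mus musculus) for cytotoxicity, tested at 10 ug/mL; on this read-out higher numbers stand for a stronger effect at the one concentration tested and lower numbers for a weaker effect. Compound 1 `COc1cc(N2C(N)=C(C#N)C(c3cccc([N+](=O)[O-])c3)C3=C2CC(C)(C)CC3=O)cc(OC)c1OC` gives 5% in this assay, and compound 2 `COc1cc(N2C(N)=C(C#N)C(c3ccccc3)C3=C2CC(C)(C)CC3=O)cc(OC)c1OC` gives 0%. Compound 2 stands at the low end of the two numbers shown, with compound 1 nearest; the step of a number 5 percentage points lower from compound 1 to compound 2 (within the scatter) lies within the scatter, so the two values are not distinguished. Compound 3 `COc1cc(N2C(N)=C(C#N)C(c3ccc(O)cc3)C3=C2CC(C)(C)CC3=O)cc(OC)c1OC` has not yet been measured. It differs from compound 2 by hydroxy in place of hydrogen on an aromatic carbon. For the measured compounds named here, the only measured step that bears on this change is the exchange on an aromatic carbon, a number 5 percentage points lower from compound 1 to compound 2 (within the scatter), which stayed within the scatter. For compound 3 the expected step is therefore a number 3 percentage points higher from compound 2 to compound 3 (within the scatter), nothing beyond the scatter in either direction. Compound 3 is thus estimated at 3%, with a range from 0% to 15%.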

Compound 3, a percentage reported as activity, at one concentration (the size of the read-out at that concentration, not a potency): 10%
Compound 3: the middle estimate sits 7 percentage points below what was measured; low and high end bracket the measured number.
By their numbers in this assay, from the lowest: compounds 2, 1 and 3 (each within the scatter of the next).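

In this assay the change of a number 10 percentage points higher from compound 2 to compound 3 (within the scatter) shows that hydroxy, placed on an aromatic carbon para to a large group, does not move the read-out beyond the scatter. The exchange of 3-nitrophenyl for 4-hydroxyphenyl gives a number 5 percentage points higher from compound 1 to compound 3 (within the scatter) and is likewise unresolved, so neither of these two substituted phenyl groups is told apart from the other or from plain phenyl on this core. No measurement at hand bears on why these numbers lie so close.

Going by these compounds, whether an amine or a carboxylic acid at this same ring carbon would lift the read-out clear of the scatter remains open. So does whether a longer chain, such as butoxy, would do so in place of the hydroxy.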